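The source may hold more compounds than are shown below. What is called first, only, known or untested is meant among the compounds shown, and "the series" means these compounds.

Of the compounds shown here, two have so far been measured in a functional assay on CHO cells for agonist activity at prostaglandin E2 receptor EP2 subtype (Homo sapiens), read by HTRF and cAMP accumulation, with a stated time of 30 min; a higher number here means that more compound is needed for the effect, a lower number that less compound is needed. Compound 1 `O=C(O)c1csc([C@H]2CC[C@@H]3[C@@H](/C=C/COc4ccccc4)[C@H](O)C[C@@H]3O2)n1` gives 3.8 nM in this assay. Compound 2 `Cc1ccc(OC[C@@H]2[C@H]3CC[C@H](c4nc(C(=O)O)cs4)O[C@H]3C[C@H]2O)cc1` gives 27 nM in this assay, which is the highest of the two numbers; the nearest number is that of compound 1, whose value is lower by a gap that lies beyond the usual scatter of repeated measurements. Compound 3 `Cc1cccc(OC[C@@H]2[C@H]3CC[C@H](c4nc(C(=O)O)cs4)O[C@H]3C[C@H]2O)c1` has not yet been measured. It differs from compound 2 in a single place: 3-methylphenyl in place of 4-methylphenyl on an oxygen on a saturated carbon. The two compounds contain the same atoms, joined differently. Among the measured compounds shown here, no measured pair shows what such a rearrangement does, so the expectation rests on the small scale of the change alone. The step of a 1.2-fold lower number from compound 2 to compound 3 (0.09 log units; within the scatter) is expected to be small, within or barely beyond the scatter, in either direction. For compound 3 the estimate in this assay is 22 nM, with a range from 7 nM to 70 nM.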

Compound 3, half-maximal effective concentration: 3.6 nM
Compound 3: middle estimate off by 6.1-fold (0.79 log units), on the high side, outside the stated range (below it).
By their numbers in this assay, from the lowest: compounds 3 and 1 (each within the scatter of the next); then compound 2.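

In this assay, putting 3-methylphenyl in place of 4-methylphenyl on an oxygen on a saturated carbon gives a 7.5-fold lower number from compound 2 to compound 3 (0.88 log units; beyond the scatter), a step beyond the scatter, although no atom is gained or lost. At this position, then, the result depends on how the methyl group is placed on the aromatic ring, so a swap between these two isomers cannot be treated as a minor change in this series. Nothing available here explains why the two isomers differ.

From the compounds shown here alone, it remains open whether this gain is specific to the methyl group or would also appear with 3-chlorophenyl or 3-methoxyphenyl. It is also unknown how 2-methylphenyl would compare, and compound 1 cannot settle either question, since it differs from compound 2 and compound 3 in more than one place.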